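Swapping the aryl group on the ring nitrogen once more

This account rests on a few compounds, and the source may have more. Where it says the series, first, only, none or still open, it means among the compounds named here.

Two compounds share one core and differ only in the aromatic group attached to an amine nitrogen in a ring. Compound 1 `Nc1scc(CN2CCN(c3cc(Cl)cc(Cl)c3)CC2)c1C(=O)c1ccc(Cl)cc1` carries a 3,5-dichlorophenyl there and compound 2 `Nc1scc(CN2CCN(c3ccccc3C(F)(F)F)CC2)c1C(=O)c1ccc(Cl)cc1` a 2-(trifluoromethyl)phenyl. In an assay on CHO cells for displacement of a labelled ligand from adenosine receptor A3 (Homo sapiens), read by scintillation counting, with a stated time of 120 min, tested at 10 uM (a higher number here means more inhibition at the concentration tested (going by the name of the read-out), a lower number less inhibition), compound 1 gives 1%, and compound 2 gives 0%. Among the measured compounds shown here, compound 2 thus holds the lowest of the two numbers, yet the only measured step, a number 1 percentage points lower from compound 1 to compound 2 (within the scatter), lies within the scatter, so the two compounds cannot be told apart on these numbers; both show almost no displacement of the labelled ligand.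

Compound 3 `Nc1scc(CN2CCN(c3ccc(Cl)c(C(F)(F)F)c3)CC2)c1C(=O)c1ccc(Cl)cc1` is the next variation of the same place: 4-chloro-3-(trifluoromethyl)phenyl in place of 2-(trifluoromethyl)phenyl on an amine nitrogen in a ring. For the measured compounds named here, the one step that bears on this kind of change is the exchange of aryl groups from compound 1 to compound 2, and it was small. With both measured compounds near zero, no step beyond the scatter is expected in this assay for compound 3, so the estimated step is a number 3 percentage points higher from compound 2 to compound 3 (within the scatter). Compound 3 is therefore expected to give about 3%, within a range of -8% to 15%.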

Compound 3, a percentage reported as inhibition, at one concentration (the size of the read-out at that concentration, not a potency): 3%
For compound 3 middle estimate and measured number coincide at the digits printed, and the stated range covers the measured number.
By their numbers in this assay, from the lowest: compounds 2, 1 and 3 (each within the scatter of the next).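

Placing a 4-chloro-3-(trifluoromethyl)phenyl on the ring nitrogen combines a chlorine and a trifluoromethyl group on one aromatic ring, and in this assay this gives a number 3 percentage points higher from compound 2 to compound 3 (within the scatter) and also a number 2 percentage points higher from compound 1 to compound 3 (within the scatter) as the comparison with the dichlorinated compound. With this third aryl group, the position now has three different substitution patterns that cannot be told apart in this test, and all three numbers remain close to zero, so the new group adds no measurable displacement of the labelled ligand that the earlier two lacked. Nothing measured here offers an explanation for these uniformly low numbers.

The compounds shown all carry a chlorinated or trifluoromethylated phenyl group at this place, so it remains open whether a different group, such as a pyridine ring, a phenyl bearing a methoxy group or a carboxylic acid, would give a number beyond the scatter. From the compounds shown here alone, it is also open whether these aryl groups would behave differently if the 4-chlorophenyl on the carbonyl of the shared core were replaced, for example by a plain phenyl.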